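Aryl amine in place of a urea on a quinoxaline-type core

The source may hold more compounds than are shown below. What is called first, only, known or untested is meant among the compounds shown, and "the series" means these compounds.

Compound 3, with the structure `CCNC(=O)Nc1nccc2nc(-c3ccccc3)cnc12`, has no number in an assay on isolated protein for inhibition of homeodomain-interacting protein kinase 1 (Homo sapiens), read by AlphaScreen, with a stated time of 1 h; a higher number here means a weaker inhibitor, a lower number a stronger inhibitor: compound 3 gives the limit > 100000 nM. Two related compounds share this situation. Compound 1, `C=CCNC(=O)Nc1cncc2nc(-c3ccccc3)cnc12`, also gives only the limit > 100000 nM in this assay. Compound 2, `Fc1ccc(Nc2cncc3nc(-c4ccccc4)cnc23)cc1Cl`, likewise gives the limit > 100000 nM in this assay. Within the data shown here, the one step among them, a step that the two limits leave unreadable from compound 1 to compound 2, cannot be read, because of the limit of > 100000 nM in this assay, at which 3 of the 3 values shown sit.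

Compound 4, `COc1ccccc1Nc1nccc2nc(-c3ccccc3)cnc12`, has not yet been measured. It differs from compound 3 by 2-methoxyphenyl in place of ethylcarbamoyl on a nitrogen on an aromatic ring. Among the measured compounds shown here, no measured step bears directly on this change, since the only comparable exchange of a urea-type substituent for an aryl group on that nitrogen, from compound 1 to compound 2, left both ends at the limit. The closest analogy is that compound 2, which also carries an aryl group on that nitrogen, sits at the limit, so the most likely outcome for compound 4 is another limit, with some chance of a readable number.

Compound 4 is therefore expected to give about 80000 nM in this assay, with a range from 8000 nM to 500000 nM. The estimated step from compound 3 to compound 4 is an at least 1.2-fold lower number from compound 3 to compound 4 (0.09 log units; that floor lies within the scatter).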

Compound 4, half-maximal inhibitory concentration: > 100000 nM
Compound 4 was reported as a limit; the forecaster's own chance of this, stated with the estimate: 70%; middle value at least 1.2-fold (0.09 log units) from the limit.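

In this assay compound 4 gives only a limit (> 100000 nM). The step from compound 3 to compound 4 cannot be read, because both ends sit at a limit: the limit of > 100000 nM in this assay, at which 4 of the 4 values shown sit. The compounds shown leave open whether any group on that nitrogen gives a readable number in this assay and how such groups would rank.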